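From a Chloropyridyl Amide to a Pyridin-2-yl Amide

The source may hold more compounds than are shown below. What is called first, only, known or untested is meant among the compounds shown, and "the series" means these compounds.

Compound 1 `Cc1ccccc1C(=O)Nc1nnc(-c2ccc3c(c2)OCCO3)s1` carries a 2-methylphenyl group on the carbonyl carbon of its amide. In a functional assay on HeLa cells (Homo sapiens) for antiproliferative activity, read by MTT assay, with a stated time of 48 h (on this read-out higher numbers stand for an effect only at larger amounts of compound and lower numbers for an effect already at smaller amounts), compound 1 gives only a limit, > 100 ug/mL. Compound 2 `O=C(Nc1nnc(-c2ccc3c(c2)OCCO3)s1)c1ccc(Cl)nc1` carries a 6-chloropyridin-3-yl group in that position instead; the step that the two limits leave unreadable from compound 1 to compound 2 cannot be read, as the limit of > 100 ug/mL in this assay, at which 2 of the 2 values shown sit, records where both of these values sit. In this assay compound 2 likewise gives only a limit, > 100 ug/mL. Compound 3 `O=C(Nc1nnc(-c2ccc3c(c2)OCCO3)s1)c1ccccn1` differs from compound 2 in one place: pyridin-2-yl in place of 6-chloropyridin-3-yl on a carbonyl carbon. The single measured step in the series, from compound 1 to compound 2, is itself unreadable, so no change of the acyl group has yet shown a readable effect in this assay, and both measured compounds rest at the same limit. For compound 3 the expected outcome is therefore again a value at or near that limit, an estimated 150 ug/mL with a range from 50 ug/mL to 500 ug/mL. The step that the limit leaves unreadable from compound 2 to compound 3 is expected to be no change beyond the scatter.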

Compound 3, half-maximal effective concentration: > 100 ug/mL
Compound 3 ended at the assay's limit; the forecaster's own chance of this, stated with the estimate: 80%; the middle value does not contradict the limit.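

For the compounds shown here, no step among compound 1, compound 2 and compound 3 can be read in this assay, since each gives only a limit: the limit of > 100 ug/mL in this assay, at which 3 of the 3 values shown sit.

The compounds shown leave open whether any group on the carbonyl carbon of the shared core gives a readable value in this assay.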